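Amide aryl change on the sulfonate series

The compounds below may be only part of what the source reports. "The series", "measured", "known", "first", "only" and "open" are said of these compounds alone.

Measured compounds:
compound 1 `O=C(Oc1ccc(-c2cncn2C2CCN(C(=O)c3ccc(Cl)c(C(F)(F)F)c3)CC2)cc1)c1cccc2cnccc12` gives > 10000 nM in an assay on HEK293 cells for antagonist activity at P2X purinoceptor 7 (Homo sapiens), read by fluorescence, with a stated time of 2 h; on this read-out higher numbers stand for weaker inhibition and lower numbers for stronger inhibition.
compound 2 `O=C(c1ccc(Cl)c(C(F)(F)F)c1)N1CCC(n2cncc2-c2ccc(OS(=O)(=O)c3cccs3)cc2)CC1` gives 238 nM.
compound 3 `O=C(c1ccc(Oc2ccccc2)cc1)N1CCC(n2cncc2-c2ccc(OS(=O)(=O)c3cccc4cnccc34)cc2)CC1` gives 187 nM.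

Of the two numbers shown, compound 3 has the lowest; compound 2 sits within the scatter of it, so the two are not distinguished. The value of compound 1 is a limit of the assay, not a number (the limit of > 10000 nM in this assay, at which 1 of the 3 values shown sits). For the measured compounds named here, the only step between measured compounds is an at least 42-fold lower number from compound 1 to compound 2 (1.62 log units; beyond the scatter), a change on the oxygen at the far end of the shared core.

Compound 4 `CC(C)(O)c1ccc(C(=O)N2CCC(n3cncc3-c3ccc(OS(=O)(=O)c4cccc5cnccc45)cc3)CC2)cc1` differs from compound 3 at the amide aryl: 1-hydroxy-1-methylethyl in place of phenoxy on an aromatic carbon. Going by the values given here, no measured step touches this part of the molecule; the change on the sulfonate side from compound 1 to compound 2 gives no guide to it. With the amide aryl otherwise unexplored here, the expectation is a step of no set direction and, in the absence of evidence, none beyond the scatter, expressed as a 1.5-fold higher number from compound 3 to compound 4 (0.18 log units; within the scatter). Compound 4 is therefore estimated at 280 nM, within 80 nM to 1000 nM, with the range kept wide.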

Compound 4, half-maximal inhibitory concentration: 109 nM
For compound 4 the middle estimate is 2.6-fold (0.41 log units) above the measured one, and the stated range covers the measured number.
By their numbers in this assay, from the lowest: compounds 4, 3 and 2 (each within the scatter of the next, the first and the last beyond it). At a limit, above all of these: compound 1.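

For the compounds shown here, the first measured step at the amide aryl in this assay is a 1.7-fold lower number from compound 3 to compound 4 (0.23 log units; within the scatter) and leaves the two compounds undistinguished. At this place, on an aromatic carbon para to a large group, phenoxy with its six-membered aromatic ring can give way to the ring-free 1-hydroxy-1-methylethyl, which has a hydrogen-bond donor, with no change beyond the scatter, so this ring is not needed here for the read-out to hold. Nothing shown gives a cause for this outcome.

The compounds shown leave open how an amine, a carboxylic acid or a plain isopropyl group would read at this place, and so whether the hydroxyl counts for anything. Compound 2 differs from compound 3 and compound 4 at both the amide aryl and the sulfonate aryl, so the two parts remain unseparated.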